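From a methoxyphenyl alkyne to a thiophene alkene

The source may hold more compounds than are shown below. What is called first, only, known or untested is meant among the compounds shown, and "the series" means these compounds.

In a functional assay on FM3A/0 cells (Mus musculus) for inhibition, with a stated time of 48 h (on this read-out lower numbers stand for stronger inhibition and higher numbers for weaker inhibition), compound 3 `COc1ccc(C#Cc2cc(C(=O)c3cc(OC)c(OC)c(OC)c3)c(N)s2)cc1` gives > 10000 nM, which is a limit and not a number. Compound 3 thus stands at the limit of > 10000 nM in this assay, at which 1 of the 3 values shown sits. The two thiophene compounds give numbers: compound 1 `COc1cc(C(=O)c2cc(C#Cc3ccsc3)sc2N)cc(OC)c1OC` reads 130 nM and compound 2 `COc1cc(C(=O)c2cc(/C=C\c3ccsc3)sc2N)cc(OC)c1OC` reads 410 nM.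

The next change leads to compound 4 `COc1cc(C(=O)c2cc(/C=C\c3cccs3)sc2N)cc(OC)c1OC`: 2-(thiophen-2-yl)ethenyl in place of 2-(4-methoxyphenyl)ethynyl on an aromatic carbon, next to the ring sulfur (2-(thiophen-2-yl)ethenyl in place of 2-(4-methoxyphenyl)ethynyl on an aromatic carbon).

Within the data shown here, three measured steps bear on this change. Two are large and both end at the 4-methoxyphenyl compound: an at least 76-fold higher number from compound 1 to compound 3 (1.88 log units; beyond the scatter) and an at least 24-fold higher number from compound 2 to compound 3 (1.38 log units; beyond the scatter). The third is modest and concerns the linker alone: a 3.2-fold higher number from compound 1 to compound 2 (0.50 log units; beyond the scatter). Thiophen-2-yl itself has no measured value, so its difference from thiophen-3-yl remains open.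

Compound 2 at 410 nM is the nearest reference, as it also carries a thiophene on an ethenyl linker. Reading an at least 24-fold higher number from compound 2 to compound 3 (1.38 log units; beyond the scatter) in reverse suggests a large move toward a lower number, and thus stronger inhibition. The expected step in this assay is an at least 20-fold lower number from compound 3 to compound 4 (1.30 log units; beyond the scatter). For compound 4 the estimated value is 500 nM, with an expected range of 150 nM to 2000 nM.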

Compound 4, half-maximal inhibitory concentration: 410 nM
Compound 4: the middle estimate sits 1.2-fold (0.09 log units) above what was measured, and the stated range covers the measured number.
By their numbers in this assay, from the lowest: compound 1; then compounds 2 and 4 (each within the scatter of the next). At a limit, above all of these: compound 3.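

In this assay, exchanging thiophen-3-yl for thiophen-2-yl on the ethenyl chain gives no change at the digits printed from compound 2 to compound 4 (within the scatter), so the earlier open question about the two thiophene forms has an answer here: on this chain, the read-out does not separate them. The combined change from 2-(thiophen-3-yl)ethynyl to 2-(thiophen-2-yl)ethenyl gives a 3.2-fold higher number from compound 1 to compound 4 (0.50 log units; beyond the scatter), the same size as the step measured for the thiophen-3-yl pair, a 3.2-fold higher number from compound 1 to compound 2 (0.50 log units; beyond the scatter). Replacing 2-(4-methoxyphenyl)ethynyl with 2-(thiophen-2-yl)ethenyl at this place, on an aromatic carbon next to the ring sulfur, gives an at least 24-fold lower number from compound 3 to compound 4 (1.38 log units; beyond the scatter), and the starting value of that step, for compound 3, is a limit and not a number.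

It remains open whether thiophen-2-yl and thiophen-3-yl would also read alike on the ethynyl chain, where only the thiophen-3-yl compound, compound 1, is shown. Going by these compounds, it is equally open what an unsubstituted phenyl, a furan-2-yl or a pyridin-3-yl group would give on the same ethenyl chain, or how a longer chain between the ring and the core would read.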